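Thiophene re-enters at the saturated ring carbon, attached differently

This account rests on a few compounds, and the source may have more. Where it says the series, first, only, none or still open, it means among the compounds named here.

Compound 3 `CC1=C(C(=O)OC(C)C)C(c2ccco2)N/C(=N/C#N)N1` gives 4% in an assay on HeLa cells for displacement of a labelled ligand from adenosine receptor A3 (Homo sapiens), with a stated time of 180 min, tested at 1 uM (a higher number here means more inhibition at the concentration tested (going by the name of the read-out), a lower number less inhibition), the lowest of the three numbers, though its gap to compound 1 stays within the scatter. Compound 1 `CC1=C(C(=O)OC(C)C)C(c2ccccc2)N/C(=N/C#N)N1` gives 6% in this assay, and compound 2 `CC1=C(C(=O)OC(C)C)C(c2cccs2)N/C(=N/C#N)N1` gives 27%. The step of a number 2 percentage points lower from compound 1 to compound 3 (within the scatter) is within the scatter, whereas a number 23 percentage points lower from compound 2 to compound 3 (beyond the scatter) and a number 21 percentage points higher from compound 1 to compound 2 (beyond the scatter) lie beyond it. Compound 4 `CC1=C(C(=O)OC(C)C)C(c2ccsc2)N/C(=N/C#N)N1` changes the same carbon: thiophen-3-yl in place of furan-2-yl on a saturated ring carbon. The step bearing on it is a number 23 percentage points lower from compound 2 to compound 3 (beyond the scatter), which compound 4 partly reverses by bringing a thiophene ring back, at another attachment point. A modest rise is therefore expected for compound 4, as a number 11 percentage points higher from compound 3 to compound 4 (beyond the scatter). Compound 4 is estimated at 15%, with a range of 2% to 35%.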

Compound 4, a percentage reported as inhibition, at one concentration (the size of the read-out at that concentration, not a potency): 13%
Beside the measured number, compound 4's estimate is 2 percentage points above it; the range from low to high includes it.
By their numbers in this assay, from the lowest: compounds 3, 1 and 4 (each within the scatter of the next); then compound 2.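

The attachment point of the thiophene counts at this carbon: this assay shows a number 14 percentage points lower from compound 2 to compound 4 (beyond the scatter). Thiophen-3-yl does not separate from the other rings, with a number 9 percentage points higher from compound 3 to compound 4 (within the scatter) and a number 7 percentage points higher from compound 1 to compound 4 (within the scatter), so among these four compounds only compound 2 stands apart. No measurement given here accounts for the difference between the two thiophene attachments.

Open, going by these compounds, is whether a methyl or chlorine on the thiophen-2-yl ring would raise the number further. Also open, on these data alone, is how a saturated cyclohexyl group would behave at this carbon.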